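The source may hold more compounds than are shown below. What is called first, only, known or untested is meant among the compounds shown, and "the series" means these compounds.

In a functional assay on LoVo cells (Homo sapiens) for inhibition, read by MTT assay, with a stated time of 24 h (a lower number here means a stronger inhibitor, a higher number a weaker inhibitor), compound 1 `CC1(C)[C@H]2CC[C@]1(C)N(Cc1cn(-c3cccc(C#N)c3)nn1)C(=O)C2` gives 320 nM, the higher of the two numbers measured, although compound 2 `CC1(C)[C@H]2CC[C@]1(C)N(Cc1cn(-c3ccccc3Cl)nn1)C(=O)C2` gives 190 nM and a 1.7-fold lower number from compound 1 to compound 2 (0.23 log units; within the scatter). Compound 3 `Cc1cccc(-n2cc(CN3C(=O)C[C@@H]4CC[C@@]3(C)C4(C)C)nn2)c1` differs from compound 1 by methyl in place of cyano on an aromatic carbon. For the measured compounds named here, no measured step makes this exchange; the only step measured, changing the same ring, stays within the scatter, so nothing argues for a shift beyond it. For compound 3 the expected step is therefore a 1.1-fold lower number from compound 1 to compound 3 (0.03 log units; within the scatter), no larger than the scatter. Compound 3 is thus estimated at 300 nM, between 120 nM and 800 nM.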

Compound 3, half-maximal inhibitory concentration: 50 nM
Compound 3: middle estimate off by 6.0-fold (0.78 log units), on the high side, outside the stated range (below it).
By their numbers in this assay, from the lowest: compound 3; then compounds 2 and 1 (each within the scatter of the next).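

Changes on this ring had so far stayed within the scatter, but here the ring substituent clearly matters in this assay: methyl in place of cyano, on an aromatic carbon meta to a large group, gives a 6.4-fold lower number from compound 1 to compound 3 (0.81 log units; beyond the scatter). The comparison with the 2-chlorophenyl compound points the same way, with a 3.8-fold lower number from compound 2 to compound 3 (0.58 log units; beyond the scatter). Nothing available explains why the number falls.

Open, on these data alone, is whether the gain belongs to methyl itself, or whether ethyl or an amine at the same place would match it. The compounds also leave open how methyl behaves elsewhere on the ring.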